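This account rests on a few compounds, and the source may have more. Where it says the series, first, only, none or still open, it means among the compounds named here.

The series shares one core; compound 3 `Cc1ccccc1N/C(=N\C#N)N1CCN(C(=O)Cc2cccs2)C(c2ccccc2)C1` carries the thiophen-2-yl on the saturated chain carbon bound to the carbonyl carbon. In a functional assay for antagonist activity at P2X purinoceptor 7 (Homo sapiens), read by FLIPR and calcium flux (on this read-out higher numbers stand for weaker inhibition and lower numbers for stronger inhibition), compound 3 gives 46 nM, the second highest of the three numbers in hand. Its nearest neighbour is compound 2 `Cc1ccccc1N/C(=N\C#N)N1CCN(C(=O)Cc2cccnc2)C(c2ccccc2)C1`, which in this assay gives 40 nM; the step of a 1.2-fold higher number from compound 2 to compound 3 (0.06 log units; within the scatter) is within the scatter, so the two are read as equivalent. Compound 1 `Cc1ccccc1N/C(=N\C#N)N1CCN(C(=O)Cc2ccoc2)C(c2ccccc2)C1` gives 220 nM in this assay, and the step of a 4.8-fold lower number from compound 1 to compound 3 (0.68 log units; beyond the scatter) is the only clear separation in the set; the parallel step a 5.5-fold lower number from compound 1 to compound 2 (0.74 log units; beyond the scatter) is of the same size.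

The step to compound 4 `Cc1ccccc1N/C(=N\C#N)N1CCN(C(=O)Cc2c[nH]cn2)C(c2ccccc2)C1` is 1H-imidazol-4-yl in place of thiophen-2-yl on a saturated chain carbon bound to a carbonyl carbon. Among the compounds with values here, no measured step exchanges a ring with sulfur for one bearing a hydrogen-bond donor, so the bearing data are indirect: the two groups with a ring nitrogen or a ring sulfur, in compounds 2 and 3, sit together, while the furan-3-yl of compound 1 sits apart. The expectation for compound 4 is therefore a step of a 1.7-fold higher number from compound 3 to compound 4 (0.24 log units; within the scatter), most likely within or only just beyond the scatter, with the direction uncertain. The estimate for compound 4 in this assay is 80 nM, with a range from 25 nM to 300 nM.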

Compound 4, half-maximal inhibitory concentration: 1000 nM
Compound 4: the middle estimate sits 13-fold (1.10 log units) below what was measured; measured number outside the range, above it.
By their numbers in this assay, from the lowest: compounds 2 and 3 (each within the scatter of the next); then compound 1; then compound 4.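

Exchanging the thiophen-2-yl for 1H-imidazol-4-yl on the saturated chain carbon bound to the carbonyl carbon gives a 22-fold higher number from compound 3 to compound 4 (1.34 log units; beyond the scatter) in this assay, and the exchange from the pyridin-3-yl gives a 25-fold higher number from compound 2 to compound 4 (1.40 log units; beyond the scatter), so the equivalence of compounds 2 and 3 does not extend to every heteroaromatic ring at this place. Even the furan-3-yl, previously the clear outlier, gives a 4.5-fold higher number from compound 1 to compound 4 (0.66 log units; beyond the scatter), which makes compound 4 the weakest of the four, and it is also the only one whose ring carries a hydrogen-bond donor, although the heavy-atom count is unchanged from the thiophen-2-yl. This link rests on a single compound, and nothing available accounts for the loss in activity.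

As far as these compounds go, it remains open whether the ring hydrogen on nitrogen or the ring itself tracks with the higher number, a question that 1-methyl-1H-imidazol-4-yl at this place would help to separate. The compounds shown also leave open how a plain phenyl or a pyrazol-4-yl would compare with the thiophen-2-yl and pyridin-3-yl.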